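This account rests on a few compounds, and the source may have more. Where it says the series, first, only, none or still open, it means among the compounds named here.

Compound 1 `CCC(C)Sc1nc(Cc2c(F)cccc2Cl)cc(=O)[nH]1`: > 76000 nM (a limit)
Compound 2 `CC(C)Sc1nc(C(C)c2c(F)cccc2Cl)cc(=O)[nH]1`: > 75000 nM (a limit)
Compound 3 `CCCSc1nc(C(C)c2c(F)cccc2Cl)cc(=O)[nH]1`: > 75000 nM (a limit)

In an ADME assay on MT4 cells (Homo sapiens) for activation, read by MTT assay (on this read-out higher numbers stand for lower toxicity in this test and lower numbers for higher toxicity in this test), none of these compounds has yet given a number. Compound 3 stands only at a limit, > 75000 nM. The whole picture consists of the limit of > 75000 nM in this assay, at which 2 of the 3 values shown sit, and (the limit of > 76000 nM in this assay, at which 1 of the 3 values shown sits).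

Compound 4 `CCC(C)Sc1nc(C(C)c2c(F)cccc2Cl)cc(=O)[nH]1` comes from compound 3 by a single change on the chain on sulfur: methyl in place of hydrogen on a saturated chain carbon bound to a saturated chain carbon and a sulfur. This turns propyl to sec-butyl. Going by the values given here, the one measured step that bears on it is a step that the two limits leave unreadable from compound 2 to compound 3. Compound 1, which already carries the sec-butyl chain, also reads only as a limit, > 76000 nM.

With no readable step to scale from, no change beyond the scatter is expected in this assay, and no direction can be given. The expected step is a number no higher from compound 3 to compound 4 (the limit leaves the size open). Another limit is the likeliest report. For compound 4 the estimate is 75000 nM, with an expected range from 35000 nM to 160000 nM.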

Compound 4, half-maximal cytotoxic concentration: > 73000 nM
Compound 4: only a limit was reported; the forecaster's own chance of this, stated with the estimate: 85%; the middle value is on the limit's open side.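

Compound 4 also reads only as a limit, and its steps from compound 1, compound 2 and compound 3 cannot be read. The compounds shown leave open what actual cytotoxic concentration any of the four would reach, and whether propyl, isopropyl or sec-butyl on sulfur makes any difference in this assay.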